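The compounds below may be only part of what the source reports. "The series", "measured", "known", "first", "only" and "open" are said of these compounds alone.

Of the compounds shown here, three have been measured so far in a functional assay on MDA-MB-453 cells (Homo sapiens) for cytotoxicity, read by MTT assay, with a stated time of 72 h; on this read-out lower numbers stand for stronger inhibition and higher numbers for weaker inhibition. Compound 1 `CC(C)(C)C1=CC(=O)C=C(NCCC(=O)O)C1=O` gives 94100 nM, compound 2 `CC1=CCC[C@H]2[C@](C)(CC3=CC(=O)C(N4CCC[C@H]4C(=O)O)=CC3=O)[C@@H](C)CC[C@]12C` gives 60600 nM, and compound 3 `CC1=CCC[C@H]2[C@](C)(CC3=CC(=O)C=C(N[C@@H](CC(C)C)C(=O)O)C3=O)[C@@H](C)CC[C@]12C` gives 10900 nM. Compound 3 therefore has the lowest number of the three, and its gaps to both of the others lie beyond the usual scatter of repeated measurements.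

The next compound, compound 4 `CC1=CCC[C@H]2[C@](C)(CC3=CC(=O)C=C(NCCC(=O)O)C3=O)[C@@H](C)CC[C@]12C`, keeps the core of compound 3 and differs only in the group on the amine nitrogen: 2-carboxyethyl in place of 1-carboxy-3-methylbutyl on an amine nitrogen. Put simply, 2-carboxyethyl stands in place of 1-carboxy-3-methylbutyl. For the measured compounds named here, no measured pair shows this change on its own, so its size can only be judged indirectly. Going by the values given here, the one measured compound with the 2-carboxyethyl group is compound 1, which sits on a different core and gives 94100 nM, the highest number so far. That value hints at weaker inhibition rather than stronger, though the difference in core makes it only a loose guide. The expected change is a 2.4-fold higher number from compound 3 to compound 4 (0.38 log units; beyond the scatter), a modest move towards weaker inhibition that should lie just beyond the scatter. For compound 4 the estimated value is 26000 nM, with an expected range of 10000 nM to 65000 nM.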

Compound 4, half-maximal inhibitory concentration: 3310 nM
Beside the measured number, compound 4's estimate is 7.9-fold (0.90 log units) above it; measured number outside the range, below it.
By their numbers in this assay, from the lowest: compound 4; then compound 3; then compounds 2 and 1 (each within the scatter of the next).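

In this assay, for the compounds shown here, putting 2-carboxyethyl in place of 1-carboxy-3-methylbutyl on the amine nitrogen gives a 3.3-fold lower number from compound 3 to compound 4 (0.52 log units; beyond the scatter), which is the first change in this set made in one place alone. It shows that this position on the shared core responds to the group it carries, and that here the smaller group gives the stronger inhibition, so the larger, branched 1-carboxy-3-methylbutyl group is not required for activity in this pair. The two groups have the same counts of hydrogen-bond donors and acceptors, but the entering group has 5 heavy atoms against 8 and lacks the defined stereocentre, and nothing available explains why the number falls.

A single pair cannot separate the loss of the branched side chain from the loss of the stereocentre or from the change in chain length between the amine nitrogen and the carboxylic acid. The compounds shown also leave open how a longer chain such as 3-carboxypropyl would compare on this core, and whether an ester or an amide could take the place of the carboxylic acid.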